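A few compounds are considered here, and "the series" means these few. Any claim that something is new, unique, unknown or untested is made for them only; others in the source may bear on it.

Measured in an assay on cells for displacement of a labelled ligand from adenosine receptor A1 (Homo sapiens), read by radioligand binding, with a stated time of 60 min, tested at 1 uM; on this read-out higher numbers stand for more inhibition at the one concentration tested (going by the name of the read-out) and lower numbers for less inhibition:
Compound 1, `CC(C)OC(=O)C1=C(C(F)(F)F)NC(=O)NC1c1ccsc1`, gives 23%.
Compound 2, `CC(C)OC(=O)C1=C(C(F)(F)F)NC(=O)NC1c1ccoc1`, gives 27%.
Compound 3, `CC1=C(C(=O)OCC(F)(F)F)C(c2ccsc2)NC(=O)N1`, gives 2%.

Compound 1 and compound 2 share a core and differ in one place only: furan-3-yl in place of thiophen-3-yl on a saturated ring carbon. This swap gave a number 4 percentage points higher from compound 1 to compound 2 (within the scatter), so the two numbers in this assay cannot be told apart. Compound 3 is built on a different core; how its core differs from that of compound 1 is not broken down here. Compound 3 has the lowest number of the three, and its gap to each of the other two is beyond the scatter.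

Compound 4, `CC1=C(C(=O)OCC(F)(F)F)C(c2ccoc2)NC(=O)N1`, has not yet been measured. It differs from compound 3 in this way: furan-3-yl in place of thiophen-3-yl on a saturated ring carbon. Within the data shown here, this is the same kind of change as the one from compound 1 to compound 2, but its surroundings are not identical: in compound 1 the saturated ring carbon is next to the ring atom that bears an isopropoxycarbonyl group and two ring bonds from the ring atom that bears a trifluoromethyl group, while in compound 3 it is next to the ring atom that bears a group of 8 heavy atoms and two ring bonds from the ring atom that bears a methyl group. Because the earlier swap gave a number 4 percentage points higher from compound 1 to compound 2 (within the scatter), a similarly small step is expected here: a number 3 percentage points higher from compound 3 to compound 4 (within the scatter). Compound 4 is therefore estimated to give 5% in this assay, with a likely range from 0% to 15%. This rests on a single precedent and on the low starting point of compound 3 at 2%.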

Compound 4, a percentage reported as inhibition, at one concentration (the size of the read-out at that concentration, not a potency): 13%
Compound 4: middle estimate off by 8 percentage points, on the low side; the range from low to high includes it.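

In this assay, putting furan-3-yl in place of thiophen-3-yl on the core of compound 3 gave a number 11 percentage points higher from compound 3 to compound 4 (beyond the scatter), and set beside the earlier case, the result reads: the same change on two cores in this assay, a number 4 percentage points higher (within the scatter) from compound 1 to compound 2 and a number 11 percentage points higher (beyond the scatter) from compound 3 to compound 4, 7 percentage points apart, within the scatter of two such steps. The size of this change therefore cannot be told apart on the two cores, so these two pairs give no sign that moving from one core to the other alters what the swap does. Among these compounds, this does not show that the swap brings a real gain on both cores, since only the step on the core of compound 3 lies beyond the scatter, and two pairs measured at a single concentration say nothing about potency or about how the swap would behave on any further core.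

The compounds shown carry only these two five-membered aromatic rings on the saturated ring carbon, so it stays open how a phenyl ring, an amine or a longer alkyl chain would fare at that place. The two cores also differ in more than one place, which leaves open what the methyl and trifluoromethyl groups, or the two ester groups, each contribute on their own.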